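The source may report more compounds than this note shows. Statements on the series, on what has been measured and on what is new or still open speak of the compounds shown alone.

Compound 1 `Nc1ccn(C/C=C/CCl)c(=O)n1` is the reference point of this small set. In a functional assay on L1210 cells (Mus musculus) for inhibition (a lower number here means a stronger inhibitor, a higher number a weaker inhibitor), compound 1 gives 50000 nM. Compound 2 `Nc1ccn(C/C=C/CO)c(=O)n1` carries the change described as hydroxy in place of chloro on a saturated chain carbon bound to a double-bonded chain carbon. In this assay compound 2 reaches only a limit of the assay, > 550000 nM. That change gives an at least 11-fold higher number from compound 1 to compound 2 (1.04 log units; beyond the scatter), a step whose size rests on (the limit of > 550000 nM in this assay, at which 1 of the 3 values shown sits). Compound 3 `Cc1cn(C/C=C\CCl)c(=O)[nH]c1=O` has a different core; the difference between the two cores is not broken down here. In this assay compound 3 gives 46000 nM, which sits within the usual scatter of the value of compound 1, so no order between the two is drawn. Compound 4 `Cc1cn(C/C=C\CO)c(=O)[nH]c1=O` has not yet been measured; it differs from compound 3 by hydroxy in place of chloro on a saturated chain carbon bound to a double-bonded chain carbon, the same change that turned compound 1 into compound 2. The step is expected to be a 13-fold higher number from compound 3 to compound 4 (1.12 log units; beyond the scatter), resting on the measured at least 11-fold higher number from compound 1 to compound 2 (1.04 log units; beyond the scatter), since the place of the change is the same in both pairs. For compound 4 the expected result in this assay is 600000 nM, with a range from 200000 nM to 2000000 nM, and there is a real chance that the assay again reports only a limit.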

Compound 4, half-maximal inhibitory concentration: > 1000000 nM
Compound 4 ended at the assay's limit (the forecaster's own chance of this, stated with the estimate: 60%); middle value at least 1.6-fold (0.22 log units) from the limit.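

Carried to the core of compound 3, hydroxy in place of chloro on a saturated chain carbon bound to a double-bonded chain carbon again weakens inhibition in this assay, with an at least 21-fold higher number from compound 3 to compound 4 (1.33 log units; beyond the scatter). The change therefore points the same way on both cores shown and is beyond the scatter on each, but two pairs do not show that the steps match in size: the same change on two cores in this assay, an at least 11-fold higher number (1.04 log units; beyond the scatter) from compound 1 to compound 2 and an at least 21-fold higher number (1.33 log units; beyond the scatter) from compound 3 to compound 4; the limit leaves it open whether they differ Compound 4 gives only a limit of the assay, > 1000000 nM, so the true size of this step stays unknown: the limit of > 1000000 nM in this assay, at which 1 of the 4 values shown sits.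

The compounds shown leave open whether other replacements for chloro, such as an amine or a methoxy group, would bring a similar step on these two cores. They also leave open whether the change carries over in the same direction to other cores, or to compounds with a longer chain.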